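Swapping Fluoro for Methoxy in a Cytotoxicity Test

The source may report more compounds than this note shows. Statements on the series, on what has been measured and on what is new or still open speak of the compounds shown alone.

In a functional assay on DU-145 cells (Homo sapiens) for cytotoxicity, read by trypan blue exclusion, with a stated time of 96 h (a higher number here means a weaker inhibitor, a lower number a stronger inhibitor), compound 2 (`COc1ccc(/C=C/S(=O)(=O)Nc2ccc(F)cc2)cc1`) gives 10000 nM and compound 1 (`COc1ccc(/C=C/S(=O)(=O)Nc2ccc(OC)c(F)c2)cc1`) gives 5000 nM as its value, and these two numbers lie within the scatter of each other. Compound 3 (`COc1ccc(/C=C/S(=O)(=O)Nc2ccc(OC)cc2)cc1`) differs from compound 2 in one place (methoxy in place of fluoro on an aromatic carbon): methoxy in place of fluoro on an aromatic carbon. Within the data shown here, nothing measured so far shows this change directly. The expected result is a 2.0-fold lower number from compound 2 to compound 3 (0.30 log units; within the scatter) as a small move toward a lower number, not beyond the scatter. Compound 3 is estimated at 5000 nM (likely range 1500 nM to 15000 nM).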

Compound 3, half-maximal inhibitory concentration: 5000 nM
Beside the measured number, compound 3's estimate shows no gap at the digits printed; the range from low to high includes it.
By their numbers in this assay, from the lowest: compounds 1, 3 and 2 (each within the scatter of the next).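

In this assay, methoxy in place of fluoro on an aromatic carbon, para to a large group, can now be read directly as a 2.0-fold lower number from compound 2 to compound 3 (0.30 log units; within the scatter). Hydrogen in place of fluoro on an aromatic carbon gives no change at the digits printed from compound 1 to compound 3 (within the scatter), so neither single change carries the number beyond the scatter, and no measurement at hand offers an explanation for these readings.

As far as these compounds go, whether an amine or a carboxylic acid in place of the methoxy would give a number beyond the scatter remains open. So does the outcome for a longer chain, such as ethoxy.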